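Adding One Methyl to Compound 2

A few compounds are considered here, and "the series" means these few. Any claim that something is new, unique, unknown or untested is made for them only; others in the source may bear on it.

In an ADME assay on microsomes from liver (Rattus norvegicus) for metabolic stability, read by LC-MS, using NADPH, at 37 degrees C (on this read-out higher numbers stand for a longer-lived compound and lower numbers for a shorter-lived compound), compound 1 `Cc1oc(-c2c(Cl)cccc2C(F)(F)F)nc1CN1CCC(C(=O)NCCCN2C[C@H](C)C[C@H](C)C2)CC1` gives 0.03 h. Compound 2 `Cc1ccc(-c2nc(CN3CCC(C(=O)NCCCN4C[C@H](C)C[C@H](C)C4)CC3)c(C)o2)cc1` gives > 0.5 h, which is a limit of the assay and not a number. Compound 3 `Cc1ccc(-c2nc(CN3CCC(C(=O)NCCCN4C[C@H](C)C[C@H](C)C4)CC3)c(C)o2)cc1C` differs from it by methyl in place of hydrogen on an aromatic carbon, making 4-methylphenyl into 3,4-dimethylphenyl. Among the compounds with values here, the only measured step, an at least 16-fold higher number from compound 1 to compound 2 (1.22 log units; beyond the scatter), is large, but it exchanges a different pair of groups, so it points to no clear shift here. The expected step is a number no higher from compound 2 to compound 3 (the limit leaves the size open), with none beyond the scatter anticipated. Compound 3 is estimated at 0.5 h, with a range of 0.2 h to 1 h.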

Compound 3, half-life: > 0.5 h
Compound 3 ended at the assay's limit; the forecaster's own chance of this, stated with the estimate: 50%; the middle value sits exactly at the limit.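

In this assay compound 3 gives > 0.5 h, which is a limit of the assay and not a number. The step from compound 2 made by the added methyl, which turns 4-methylphenyl into 3,4-dimethylphenyl, cannot be read because both compounds sit at the same limit: the limit of > 0.5 h in this assay, at which 2 of the 3 values shown sit. The step that can be read is an at least 16-fold higher number from compound 1 to compound 3 (1.22 log units; beyond the scatter), so the added methyl does not bring back the short half-life of compound 1.

As far as these compounds go, how long compound 2 and compound 3 actually last stays open, and so does any effect of the methyl on that time. Also open, from the compounds shown here alone, is how a nitrile or an amine in the same place would read.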